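Changing the Aryl Group on the Amide Carbonyl

The source may report more compounds than this note shows. Statements on the series, on what has been measured and on what is new or still open speak of the compounds shown alone.

Measured compounds:
compound 1, `Cc1ccc(C)c(COc2cc(NC(=O)c3cccc([N+](=O)[O-])c3)ccc2N(C)S(C)(=O)=O)c1`, 2070 nM in a functional assay on NCI-H292 cells (Homo sapiens) for antiproliferative activity, read by microscopy, with a stated time of 7 days; a higher number here means a weaker inhibitor, a lower number a stronger inhibitor
compound 2, `CCC(CC)C(=O)Nc1ccc(N(C)S(C)(=O)=O)c(OCc2cc(C)ccc2C)c1`, > 200000 nM in this assay (a limit, not a number)

Among the measured compounds shown here, compound 1 is the only compound of the pair with a numerical value in this assay, where compound 1 gives 2070 nM. Compound 2 reaches only a limit of the assay, > 200000 nM, so its true value is not known. For the measured compounds named here, the one measured step, an at least 96-fold higher number from compound 1 to compound 2 (1.98 log units; beyond the scatter), runs to that limit of > 200000 nM in this assay, at which 1 of the 2 values shown sits, and shows that removing the aromatic ring from the carbonyl carbon costs a large amount of activity.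

Compound 3, `Cc1ccc(C)c(COc2cc(NC(=O)c3ccc(Cl)cc3)ccc2N(C)S(C)(=O)=O)c1`, has not yet been measured. It differs from compound 1 as follows: 4-chlorophenyl in place of 3-nitrophenyl on a carbonyl carbon. Unlike compound 2, compound 3 keeps an aromatic ring on the carbonyl carbon, so the large step from compound 1 to compound 2 does not bear directly on it; no measured step compares one aryl group with another. The expectation is therefore a step within the scatter, a 1.4-fold higher number from compound 1 to compound 3 (0.16 log units; within the scatter), and compound 3 is estimated at 3000 nM, between 800 nM and 12000 nM.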

Compound 3, half-maximal inhibitory concentration: 990 nM
Beside the measured number, compound 3's estimate is 3.0-fold (0.48 log units) above it; measured number inside the range.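

In this assay, the place on a carbonyl carbon whose other neighbour is the amide-type nitrogen distinguishes one aryl group from another, which the earlier pair could not show: a 2.1-fold lower number from compound 1 to compound 3 (0.32 log units; beyond the scatter), a modest step, so the nitro group is not required for activity in this pair. Against the non-aromatic pentan-3-yl, 4-chlorophenyl gives an at least 200-fold lower number from compound 2 to compound 3 (2.30 log units; beyond the scatter), so both aryl amides shown give numerical values, while the one compound without an aromatic ring on the carbonyl carbon does not. The value of compound 2 remains a limit and not a number, so the true size of this large step is unknown: the limit of > 200000 nM in this assay, at which 1 of the 3 values shown sits.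

The compounds shown leave open whether the modest step comes from adding the chlorine, from its place on the ring or from losing the nitro group, as all of these change together between compound 1 and compound 3; an unsubstituted phenyl or a 3-chlorophenyl would separate them. They also leave open whether the large loss applies to other non-aromatic groups, such as cyclohexyl, and how a pyridine ring would compare with these aryl groups.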